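Moving the Acid Group in Two Bile Acid Receptor Agonist Cores

The source may hold more compounds than are shown below. What is called first, only, known or untested is meant among the compounds shown, and "the series" means these compounds.

Compound 1, `CN(Cc1cccc(C(=O)O)c1)c1ccc(OCc2c(-c3c(Cl)cccc3Cl)noc2C2CC2)nc1C(F)(F)F`: 2 nM
Compound 2, `CN(Cc1ccc(C(=O)O)cc1)c1ccc(OCc2c(-c3c(Cl)cccc3Cl)noc2C2CC2)nc1C(F)(F)F`: 6 nM
Compound 3, `CC(C)c1onc(-c2c(Cl)cccc2Cl)c1COc1cnc(N(C)Cc2ccc(C(=O)O)cc2)c(Cl)c1`: 120 nM

These three compounds were tested in a functional assay on HEK293 cells for agonist activity at Bile acid receptor (Homo sapiens), read by a luciferase reporter; a higher number here means that more compound is needed for the effect, a lower number that less compound is needed. Compound 2 and compound 1 share one core and differ only by 3-carboxyphenyl in place of 4-carboxyphenyl on a saturated chain carbon bound to a nitrogen on an aromatic ring; this change gave a 3.0-fold lower number from compound 2 to compound 1 (0.48 log units; beyond the scatter). Compound 3 carries a second core, and the difference between the two cores is not broken down here; in this assay compound 3 gives 120 nM, well above the other two.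

Compound 4, `CC(C)c1onc(-c2c(Cl)cccc2Cl)c1COc1cnc(N(C)Cc2cccc(C(=O)O)c2)c(Cl)c1`, has not yet been measured. It differs from compound 3 by 3-carboxyphenyl in place of 4-carboxyphenyl on a saturated chain carbon bound to a nitrogen on an aromatic ring, the same change as between compound 2 and compound 1. Because the earlier step was a 3.0-fold lower number from compound 2 to compound 1 (0.48 log units; beyond the scatter), the expected step here is a 3.0-fold lower number from compound 3 to compound 4 (0.48 log units; beyond the scatter), assuming the second core responds alike. The estimate for compound 4 in this assay is 40 nM, likely between 15 nM and 120 nM.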

Compound 4, half-maximal effective concentration: 61 nM
Estimate against measurement, compound 4: 1.5-fold (0.18 log units) below, within the range that was stated.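

On the second core, 3-carboxyphenyl in place of 4-carboxyphenyl gives a 2.0-fold lower number from compound 3 to compound 4 (0.29 log units; within the scatter) in this assay, and this step alone cannot be told apart from ordinary assay scatter. Set beside the step on the first core, the change behaves alike on both cores as far as these numbers can tell: the same change on two cores in this assay, a 3.0-fold lower number (0.48 log units; beyond the scatter) from compound 2 to compound 1 and a 2.0-fold lower number (0.29 log units; within the scatter) from compound 3 to compound 4, 1.5-fold (0.18 log units) apart, within the scatter of two such steps. This supports carrying the change from one of these cores to the other, but two pairs of compounds give no rule for any further core.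

The compounds shown leave open how either core would respond to an amide in place of the carboxylic acid. They also leave open the effect of a 2-phenylethyl chain in place of the benzyl group.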